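Halogen swap at the ortho position of the N-phenyl group

This account rests on a few compounds, and the source may have more. Where it says the series, first, only, none or still open, it means among the compounds named here.

Measured so far, in a functional assay on HepG2 cells (Homo sapiens) for antiproliferative activity, read by MTT assay, with a stated time of 24 h; on this read-out higher numbers stand for weaker inhibition and lower numbers for stronger inhibition:
compound 1, `O=c1[nH]cc(S(=O)(=O)Nc2ccccc2-c2cn(-c3ccccc3)nn2)c(=O)[nH]1`, gives 6160 nM
compound 2, `Cc1cccc(-n2cc(-c3ccccc3NS(=O)(=O)c3c[nH]c(=O)[nH]c3=O)nn2)c1`, gives 3620 nM
compound 3, `O=c1[nH]cc(S(=O)(=O)Nc2ccccc2-c2cn(-c3ccccc3F)nn2)c(=O)[nH]1`, gives 12500 nM

Compound 3 sits at the high end of this set of three. Its nearest neighbour is compound 1, with a 2.0-fold higher number from compound 1 to compound 3 (0.31 log units; beyond the scatter); the step from compound 2 is larger, with a 3.5-fold higher number from compound 2 to compound 3 (0.54 log units; beyond the scatter). Compound 2 and compound 1 differ only within the scatter, a 1.7-fold lower number from compound 1 to compound 2 (0.23 log units; within the scatter).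

Compound 4, `O=c1[nH]cc(S(=O)(=O)Nc2ccccc2-c2cn(-c3ccccc3Cl)nn2)c(=O)[nH]1`, has not been measured in this assay. It differs from compound 3 by chloro in place of fluoro on an aromatic carbon. The step that bears on it most directly is the one that introduced fluoro on the same aromatic carbon of the N-phenyl ring, going from compound 1 to compound 3, a modest rise in the number. Among the compounds with values here, no measured pair compares chloro with fluoro, so there is no direct guide to the direction of this exchange. The expectation for compound 4 is therefore a number close to that of compound 3, with a step of a 1.1-fold lower number from compound 3 to compound 4 (0.06 log units; within the scatter) that is not expected to exceed the scatter. The estimate for compound 4 is 11000 nM, with a range from 4500 nM to 27000 nM.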

Compound 4, half-maximal inhibitory concentration: 2240 nM
For compound 4 the middle estimate is 4.9-fold (0.69 log units) above the measured one; measured number below the stated range.
By their numbers in this assay, from the lowest: compounds 4, 2 and 1 (each within the scatter of the next, the first and the last beyond it); then compound 3.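

Working notes on the N-phenyl substituent: in this assay, the halogens on this aromatic carbon, ortho to a large group, are not interchangeable, since chloro in place of fluoro gives a 5.6-fold lower number from compound 3 to compound 4 (0.75 log units; beyond the scatter) and this is the largest step in the series so far. Compared with the unsubstituted phenyl of compound 1, the two halogens move the number in opposite directions: fluoro gives a 2.0-fold higher number from compound 1 to compound 3 (0.31 log units; beyond the scatter) while chloro gives a 2.8-fold lower number from compound 1 to compound 4 (0.44 log units; beyond the scatter) and so a substituent at this carbon can either raise or lower the number. The 2-chlorophenyl and 3-methylphenyl groups are not told apart, as a 1.6-fold lower number from compound 2 to compound 4 (0.21 log units; within the scatter) remains within the scatter.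

As far as these compounds go, whether the drop seen with chloro continues to bromo, or extends to a methyl or methoxy group on the same carbon, remains open, as does the result of placing chloro elsewhere on the ring. Nothing at hand explains the difference between the two halogens.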